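Toward a primary amide on the aryl ether of compound 1

A few compounds are considered here, and "the series" means these few. Any claim that something is new, unique, unknown or untested is made for them only; others in the source may bear on it.

Within the data shown here, compound 1 `Cc1ncc(OCCCCOc2ccc(C(=O)CC(C)(C)C)c(O)c2C)cc1C(=O)O` gives 79 nM in an assay for positive allosteric modulation of metabotropic glutamate receptor 3 (Rattus norvegicus) (a lower number here means that less compound is needed, a higher number that more compound is needed for the effect), the lowest of the three numbers measured so far. Compound 2 `Cc1c(OCCCCOc2ccc(Cl)c(C(=O)O)c2)ccc(C(=O)CC(C)(C)C)c1O` gives 130 nM, and compound 3 `CNC(=O)c1cc(OCCCCOc2ccc(C(=O)CC(C)(C)C)c(O)c2C)ccc1F` gives 476 nM. Among the measured compounds shown here, the only step between measured neighbours, a 1.6-fold higher number from compound 1 to compound 2 (0.22 log units; within the scatter), stays within the scatter, so the acid-bearing aryl groups of compound 1 and compound 2 behave alike. Compound 4 `Cc1c(OCCCCOc2ccc(F)c(C(N)=O)c2)ccc(C(=O)CC(C)(C)C)c1O` differs from compound 1 as follows: 3-carbamoyl-4-fluorophenyl in place of 5-carboxy-6-methylpyridin-3-yl on an oxygen on a saturated carbon. For the measured compounds named here, no measured step covers this exact change. The closest guidance comes from compound 3, which differs from compound 4 only by a methyl on the amide nitrogen and whose number lies well above that of compound 1. Because compound 3 gives 476 nM, compound 4 is expected to move toward higher numbers by a 4.4-fold higher number from compound 1 to compound 4 (0.65 log units; beyond the scatter). The estimate for compound 4 is 350 nM, with a range from 120 nM to 1000 nM.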

Compound 4, half-maximal effective concentration: "not active" (no number reported)
For compound 4 the study gives words and no number, so the estimate cannot be set against anything.
By their numbers in this assay, from the lowest: compounds 1 and 2 (each within the scatter of the next); then compound 3.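

Among these compounds, compound 4 is reported in this assay as "not active", without a number, so no step from compound 1 to compound 4 can be read. Nothing at hand bears on this result. The compounds shown leave open how far the 3-carbamoyl-4-fluorophenyl group of compound 4 lies from the 5-carboxy-6-methylpyridin-3-yl group of compound 1.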